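Propargylamine coumarins: swapping the benzyl substituent

A few compounds are considered here, and "the series" means these few. Any claim that something is new, unique, unknown or untested is made for them only; others in the source may bear on it.

Measured compounds:
compound 1 `C#CCN(CCCOc1ccc2ccc(=O)oc2c1)Cc1ccc(OC)cc1` gives 6080 nM in an assay on isolated protein for inhibition of Amine oxidase [flavin-containing] B (Homo sapiens), read by fluorescence and Amplex Red, with stated times of 15 min and 20 min; on this read-out higher numbers stand for weaker inhibition and lower numbers for stronger inhibition
compound 2 `C#CCN(CCCCOc1ccc2ccc(=O)oc2c1)Cc1cccc(F)c1` gives 1550 nM in this assay
compound 3 `C#CCN(CCCOc1ccc2ccc(=O)oc2c1)Cc1ccc(F)c(F)c1` gives 4860 nM in this assay

Among the three measured numbers, compound 3 stands second highest. For the measured compounds named here, its nearest neighbour is compound 1, whose value lies within the scatter of compound 3; the furthest is compound 2, whose lower number lies beyond the scatter, though compound 2 differs from compound 3 in more than one place and so gives no clean step.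

Compound 4 `C#CCN(CCCOc1ccc2ccc(=O)oc2c1)Cc1cccc(OC)c1` is the unmeasured analogue. The change from compound 3 to compound 4 is 3-methoxyphenyl in place of 3,4-difluorophenyl on a saturated chain carbon bound to an amine nitrogen. Going by the values given here, only one measured step bears on this position: a 1.3-fold lower number from compound 1 to compound 3 (0.10 log units; within the scatter), which shows that exchanging the substituted phenyl on this carbon left the number within the scatter. A methoxyphenyl is therefore already known at this place with a value close to that of compound 3. The expectation is for no step beyond the scatter, so a 1.0-fold higher number from compound 3 to compound 4 (0.01 log units; within the scatter) is estimated. Compound 4 is expected to give 5000 nM, with a range from 2000 nM to 12500 nM.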

Compound 4, half-maximal inhibitory concentration: 4590 nM
Compound 4: the middle estimate sits 1.1-fold (0.04 log units) above what was measured; low and high end bracket the measured number.
By their numbers in this assay, from the lowest: compound 2; then compounds 4, 3 and 1 (each within the scatter of the next).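

In this assay, 3-methoxyphenyl in place of 3,4-difluorophenyl on a saturated chain carbon bound to an amine nitrogen gave a 1.1-fold lower number from compound 3 to compound 4 (0.02 log units; within the scatter), so a ring with fluorine and a ring with methoxy now compare directly at this place, with the number staying within the scatter. Moving from 4-methoxyphenyl to 3-methoxyphenyl gave a 1.3-fold lower number from compound 1 to compound 4 (0.12 log units; within the scatter), which shows that the place of the methoxy on the ring made no difference beyond the scatter in this set. Nothing available accounts for why these rings read alike.

As far as these compounds go, whether an unsubstituted benzyl, or a benzyl carrying an amine or a carboxylic acid, would also stay within the scatter remains open. So does how much of the value of compound 2, 1550 nM, belongs to its chain and how much to its ring, since it differs from the others in more than one place.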